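A Fluorinated Ring Swap on Compound 3

A few compounds are considered here, and "the series" means these few. Any claim that something is new, unique, unknown or untested is made for them only; others in the source may bear on it.

Three related compounds share one core and differ in a single group on an aromatic carbon. In an ADME assay (liver) for metabolic stability, with Liver microsome (Rattus norvegicus) as the target, using microsomes and NADPH, with a stated time of 30 min, tested at 1 uM (a lower number here means slower removal, a higher number faster removal of the compound), compound 1 `CCn1cc(-c2cc(C(O)(C(F)(F)F)C(F)(F)F)cnc2N2CCN(S(=O)(=O)c3ccc(N)nc3)CC2)cn1` gives 194 mL.min-1.g-1 and compound 2 `NC(=O)c1cccc(-c2cc(C(O)(C(F)(F)F)C(F)(F)F)cnc2N2CCN(S(=O)(=O)c3ccc(N)nc3)CC2)c1` gives 63 mL.min-1.g-1. Compound 3 `Nc1ccc(S(=O)(=O)N2CCN(c3ncc(C(O)(C(F)(F)F)C(F)(F)F)cc3-c3ccncc3)CC2)cn1` gives 31 mL.min-1.g-1, the lowest of the three.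

Compound 4 `Nc1ccc(S(=O)(=O)N2CCN(c3ncc(C(O)(C(F)(F)F)C(F)(F)F)cc3-c3cnccc3F)CC2)cn1` carries 4-fluoropyridin-3-yl in place of pyridin-4-yl at that same place (4-fluoropyridin-3-yl in place of pyridin-4-yl on an aromatic carbon). Going by the values given here, all the measured steps change this place. Moving to pyridin-4-yl gave a 6.3-fold lower number from compound 1 to compound 3 (0.80 log units; beyond the scatter) and a 2.0-fold lower number from compound 2 to compound 3 (0.31 log units; beyond the scatter), while moving to 3-carbamoylphenyl gave a 3.1-fold lower number from compound 1 to compound 2 (0.49 log units; beyond the scatter). So this group can shift the number, but no measured compound carries a fluorine on this ring, and the direction for the new group is not settled.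

Compound 3 already sits lowest at 31 mL.min-1.g-1, so a slight upward lean seems reasonable, but no step beyond the scatter is expected. The expected change is a 1.3-fold higher number from compound 3 to compound 4 (0.11 log units; within the scatter). For compound 4 the estimated value is 40 mL.min-1.g-1, with an expected range from 18 mL.min-1.g-1 to 90 mL.min-1.g-1.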

Compound 4, intrinsic clearance in microsomes: 22 mL.min-1.g-1
The estimate for compound 4 lay 1.8-fold (0.26 log units) above the measured number; low and high end bracket the measured number.
By their numbers in this assay, from the lowest: compounds 4 and 3 (each within the scatter of the next); then compound 2; then compound 1.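

The fluorine-bearing ring holds the low end of this assay: 4-fluoropyridin-3-yl in place of pyridin-4-yl gives a 1.4-fold lower number from compound 3 to compound 4 (0.15 log units; within the scatter), so compound 3 and compound 4 cannot be told apart here. The second pyridine-based group also keeps the gap to the other two groups, with a 2.9-fold lower number from compound 2 to compound 4 (0.46 log units; beyond the scatter) and an 8.8-fold lower number from compound 1 to compound 4 (0.95 log units; beyond the scatter), so among these four compounds the two carrying a pyridinyl group give the lowest numbers. Nothing measured here explains these numbers.

This step changes both the ring's point of attachment and the fluorine, so the compounds shown do not separate the two, and plain pyridin-3-yl would be needed to do that. As far as these compounds go, how an amine or a carboxylic acid on this ring would behave also remains open.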